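The source may hold more compounds than are shown below. What is called first, only, known or untested is meant among the compounds shown, and "the series" means these compounds.

Compound 1 `CCCc1nc(C)c2c(C(C)C)nnc(S)n12` carries an isopropyl group. In a functional assay for inhibition, with Homo sapiens as the target (a higher number here means a weaker inhibitor, a lower number a stronger inhibitor), compound 1 reaches only a limit of > 48000 nM. Compound 2 `CCc1nc(C)c2cnnc(SC)n12` has a different core; the difference between the two cores is not broken down here. In this assay compound 2 likewise gives a limit of > 48000 nM. Compound 3 `CSc1nncc2c(C)nc(C)n12` differs from compound 2 by hydrogen in place of methyl on a saturated chain carbon bound to an aromatic carbon. In this assay compound 3 gives a limit of > 48000 nM. Because the limit of > 48000 nM in this assay, at which 3 of the 3 values shown sit, holds both values, the step that the two limits leave unreadable from compound 2 to compound 3 cannot be read. Compound 4 `CCCc1nc(C)c2c(CC)nnc(S)n12` differs from compound 1 by hydrogen in place of methyl on a saturated chain carbon bound to an aromatic carbon and a saturated chain carbon, the same kind of change, though here the saturated chain carbon is bound to an aromatic carbon and a saturated chain carbon rather than to an aromatic carbon alone. Because the limit of > 48000 nM in this assay, at which 3 of the 3 values shown sit, covers every measured value, the step that the limit leaves unreadable from compound 1 to compound 4 is expected to be small. Compound 4 is therefore expected to give about 60000 nM in this assay, most likely once more only a limit.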

Compound 4, half-maximal inhibitory concentration: > 48000 nM
Compound 4: only a limit was reported; the forecaster's own chance of this, stated with the estimate: 85%; the middle value does not contradict the limit.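

Compound 1 and compound 4 both give only a limit, so no step from isopropyl to ethyl can be read between them: the limit of > 48000 nM in this assay, at which 4 of the 4 values shown sit.

The compounds shown leave open whether this change alters inhibition at all in this assay.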